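The source may hold more compounds than are shown below. What is called first, only, known or untested is meant among the compounds shown, and "the series" means these compounds.

In a functional assay on HT-29 cells (Homo sapiens) for cytotoxicity, read by MTT assay (a lower number here means a stronger inhibitor, a higher number a weaker inhibitor), three compounds that share one core and differ only in the five-membered aromatic ring on the chain have been measured. Compound 1 `COc1ccc(OC)c(C(=O)/C=C/c2ccoc2)c1` gives 21300 nM, compound 2 `COc1ccc(OC)c(C(=O)/C=C/c2cccs2)c1` gives 13300 nM, and compound 3 `COc1ccc(OC)c(C(=O)/C=C/c2ccsc2)c1` gives 5300 nM. The lowest number of the three belongs to compound 3. The data show a 2.5-fold lower number from compound 2 to compound 3 (0.40 log units; beyond the scatter) and a 4.0-fold lower number from compound 1 to compound 3 (0.60 log units; beyond the scatter), whereas a 1.6-fold lower number from compound 1 to compound 2 (0.20 log units; within the scatter).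

Compound 4 `COc1ccc(OC)c(C(=O)/C=C/c2ccc(C)o2)c1` has 5-methylfuran-2-yl in place of thiophen-3-yl on a double-bonded chain carbon bound to a double-bonded chain carbon. The closest measured change is the exchange between furan-3-yl and thiophen-3-yl, which, read in reverse, points towards a higher number, with a size set by a 4.0-fold lower number from compound 1 to compound 3 (0.60 log units; beyond the scatter). The other relevant step is a 2.5-fold lower number from compound 2 to compound 3 (0.40 log units; beyond the scatter), which shows that the thiophen-2-yl compound also has a higher number than the thiophen-3-yl compound. Within the data shown here, no measured compound carries the methyl group or a furan-2-yl ring, so that part of the change is untested. A modest rise in the number is therefore expected in this assay. The estimate corresponds to a 2.3-fold higher number from compound 3 to compound 4 (0.35 log units; beyond the scatter). For compound 4 the expected value is 12000 nM, within an estimated range of 4500 nM to 30000 nM.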

Compound 4, half-maximal inhibitory concentration: 43000 nM
Compound 4: the middle estimate sits 3.6-fold (0.55 log units) below what was measured; measured number outside the range, above it.
By their numbers in this assay, from the lowest: compound 3; then compounds 2 and 1 (each within the scatter of the next); then compound 4.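

In this assay, among these compounds, 5-methylfuran-2-yl on a double-bonded chain carbon bound to a double-bonded chain carbon gives the highest number so far, with an 8.1-fold higher number from compound 3 to compound 4 (0.91 log units; beyond the scatter), a 3.2-fold higher number from compound 2 to compound 4 (0.51 log units; beyond the scatter) and a 2.0-fold higher number from compound 1 to compound 4 (0.31 log units; beyond the scatter). The step from thiophen-3-yl to this ring is larger than a 4.0-fold lower number from compound 1 to compound 3 (0.60 log units; beyond the scatter), the widest step among the earlier compounds, so the spread of numbers at this place is greater than those three rings alone had shown. Nothing given here accounts for the rise seen with compound 4.

Compound 4 differs from the earlier compounds in both its ring and its methyl group, and the compounds shown include neither a furan-2-yl ring without the methyl nor a thiophene ring bearing one, so the contributions of the two cannot be separated. As far as these compounds go, it also remains open how the number would respond if the methyl on the furan ring gave way to an ethyl group, an amine or a carboxylic acid.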